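Will a (1H-tetrazol-5-yl)methyl group shorten the half-life?

A few compounds are considered here, and "the series" means these few. Any claim that something is new, unique, unknown or untested is made for them only; others in the source may bear on it.

In an ADME assay on microsomes from liver (Mus musculus) for metabolic stability (a higher number here means that the compound lasts longer, a lower number that the compound disappears faster), compound 3 `CC(C)C(c1ccc(-c2ccc3cccc(F)c3c2)[nH]c1=O)N1CCN/C1=N\C#N` gives 0.207 h, the only result so far that is a real number. Compound 1 `CC(C)C(Cc1ncc[nH]1)c1ccc(-c2ccc3cccc(F)c3c2)[nH]c1=O` gives < 0.0667 h, which is a limit of the assay. Compound 2 `CC(C)C(Cc1nnc[nH]1)c1ccc(-c2ccc3cccc(F)c3c2)[nH]c1=O` gives < 0.0667 h, which is also a limit.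

The next compound, compound 4 `CC(C)C(Cc1nnn[nH]1)c1ccc(-c2ccc3cccc(F)c3c2)[nH]c1=O`, differs from compound 3 as follows: a group of 6 heavy atoms (2 carbon, 4 nitrogen; one five-membered aromatic ring with 4 hetero atoms) in place of a group of 8 heavy atoms (4 carbon, 4 nitrogen; one five-membered non-aromatic ring with 2 hetero atoms), on a saturated chain carbon bound to an aromatic carbon and a saturated chain carbon. Like compound 1 and compound 2, it therefore carries a five-membered aromatic ring where compound 3 has a five-membered non-aromatic ring.

Within the data shown here, two measured steps bear on this change, both beyond the scatter: an at least 3.1-fold higher number from compound 1 to compound 3 (0.49 log units; beyond the scatter) and an at least 3.1-fold higher number from compound 2 to compound 3 (0.49 log units; beyond the scatter). The third comparison, a step that the two limits leave unreadable from compound 1 to compound 2, gives no usable size. Compound 4 reverses the kind of ring change seen in those two readable steps, so a fall in this assay is expected. The expected change is a 2.6-fold lower number from compound 3 to compound 4 (0.41 log units; beyond the scatter). For compound 4, the estimated half-life is 0.08 h, with an expected range from 0.03 h to 0.25 h.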

Compound 4, half-life: 0.853 h
Compound 4: the middle estimate sits 11-fold (1.03 log units) below what was measured, and the stated range ends below it.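

Compound 1 and compound 2 suggested that a five-membered aromatic ring on this saturated chain carbon goes with a short half-life in this assay but the (1H-tetrazol-5-yl)methyl group overturns that reading with a 4.1-fold higher number from compound 3 to compound 4 (0.61 log units; beyond the scatter). So the atoms of the aromatic ring matter here, not just its being aromatic: 1H-tetrazol-5-yl in place of 4H-1,2,4-triazol-3-yl gives an at least 12-fold higher number from compound 2 to compound 4 (1.10 log units; beyond the scatter) and 1H-tetrazol-5-yl in place of 1H-imidazol-2-yl gives an at least 12-fold higher number from compound 1 to compound 4 (1.10 log units; beyond the scatter). Both of these sizes are minimums, as one end of each step is a limit and not a number: the limit of < 0.0667 h in this assay, at which 2 of the 4 values shown sit.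

Still open, as far as these compounds go, is whether a carboxylic acid on the same chain, or a longer chain carrying the tetrazole, would last as long as compound 4. Also open, from the compounds shown here alone, is whether a methyl group on the tetrazole would keep this half-life, and the step from compound 1 to compound 2 cannot be read.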